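From Phenyl to Pyridin-4-yl on a Shared Core

The source may hold more compounds than are shown below. What is called first, only, known or untested is meant among the compounds shown, and "the series" means these compounds.

In a functional assay on MIA PaCa-2 cells (Homo sapiens) for antiproliferative activity, read by MTT assay, with a stated time of 24 h (on this read-out lower numbers stand for stronger inhibition and higher numbers for weaker inhibition), compound 2 `COc1ccc(-c2noc(-c3ccccc3)n2)cc1OC1CCCC1` gives > 1000000 nM, which is a limit and not a number. Compound 3 `COc1ccc(-c2noc(-c3ccncc3)n2)cc1OC1CCCC1` differs from it by having pyridin-4-yl in place of phenyl on an aromatic carbon of the shared core (pyridin-4-yl in place of phenyl on an aromatic carbon). Compound 1 `c1ccc(-c2noc(-c3ccncc3)n2)cc1` also carries pyridin-4-yl and gives 497000 nM in this assay, which is the only basis for expecting a change. A modest move towards stronger inhibition is therefore expected, with an estimated step of an at least 2.2-fold lower number from compound 2 to compound 3 (0.34 log units; beyond the scatter). The estimated value for compound 3 is 450000 nM, within an expected range of 120000 nM to 1000000 nM.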

Compound 3, half-maximal inhibitory concentration: 9330 nM
For compound 3 the middle estimate is 48-fold (1.68 log units) above the measured one; measured number below the stated range.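

In this assay, this position on the shared core proves highly sensitive to the change: pyridin-4-yl in place of phenyl gives an at least 100-fold lower number from compound 2 to compound 3 (2.03 log units; beyond the scatter). Within the data shown here, the entering ring differs from the leaving one by 1 hetero atom and 1 hydrogen-bond acceptor, yet the earlier compounds gave no measure of what this change does on this core. As far as these compounds go, the value of compound 2 is a limit and not a number, so the step's full size stays unknown: the limit of > 1000000 nM in this assay, at which 1 of the 3 values shown sits. The compounds shown leave open how pyridin-3-yl, pyridin-2-yl or a phenyl ring bearing an amine would fare at this position.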